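This account rests on a few compounds, and the source may have more. Where it says the series, first, only, none or still open, it means among the compounds named here.

Measured in a functional assay on LNCaP C4-2B cells (Homo sapiens) for antiproliferative activity, read by luminescence, with a stated time of 96 h; a lower number here means a stronger inhibitor, a higher number a weaker inhibitor:
- compound 1 `COc1cc2c(cc1NS(=O)(=O)c1cc(Br)ccc1OC)OC(C)(C)C(=O)N2`: 3230 nM
- compound 2 `COc1ccc(Br)cc1S(=O)(=O)Nc1cc2c(cc1O)NC(=O)C(C)(C)O2`: 7750 nM

Going by the values given here, compound 2 has the higher number of the two, and its only neighbour is compound 1, at 3230 nM. Compound 3 `COc1ccc(Br)cc1S(=O)(=O)Nc1ccc2c(c1)OC(C)(C)C(=O)N2` has not yet been measured. It carries hydrogen in place of hydroxy on an aromatic carbon. Among the compounds with values here, one measured step bears on this change, a 2.4-fold higher number from compound 1 to compound 2 (0.38 log units; beyond the scatter), which is modest and involves the same oxygen, where hydrogen takes the place of methyl. Within the data shown here, no measured compound yet shows hydrogen on that aromatic carbon, so this step is only a rough guide. A modest step towards a lower number is therefore expected in this assay. The expected step is a 2.2-fold lower number from compound 2 to compound 3 (0.35 log units; beyond the scatter). The estimated value for compound 3 is 3500 nM, within an expected range of 1200 nM to 10000 nM.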

Compound 3, half-maximal inhibitory concentration: 6560 nM
Estimate against measurement, compound 3: 1.9-fold (0.27 log units) below, and the stated range covers the measured number.
By their numbers in this assay, from the lowest: compound 1; then compounds 3 and 2 (each within the scatter of the next).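

With hydrogen in place of hydroxy on this aromatic carbon, this assay shows a 1.2-fold lower number from compound 2 to compound 3 (0.07 log units; within the scatter) and so does not separate these two groups. Hydrogen in place of methoxy on the same carbon gives a 2.0-fold higher number from compound 1 to compound 3 (0.31 log units; beyond the scatter), in the same direction as a 2.4-fold higher number from compound 1 to compound 2 (0.38 log units; beyond the scatter), so among these three compounds the methoxy of compound 1 alone stands apart, and only modestly. Nothing available explains why methoxy differs from both hydroxy and hydrogen here.

The compounds shown leave open whether the gain is particular to methoxy or would extend to a longer chain such as ethoxy on this carbon. They also leave open how an amine or a chlorine atom at this place would compare in this assay.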